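Chloro to Amino on the Fused Ring: An Open Question

This account rests on a few compounds, and the source may have more. Where it says the series, first, only, none or still open, it means among the compounds named here.

Compound 1: `Nc1nn(C(=O)Nc2ccc(Cc3ccccc3)cc2)c2ccccc12` — 58200 nM
Compound 2: `Nc1nn(C(=O)Nc2ccc(Cc3ccccc3)cc2)c2ccc(Cl)cc12` — 31500 nM

Of the compounds shown here, two have been tested in a functional assay on RXF 393 cells (Homo sapiens) for antiproliferative activity, read by sulforhodamine B assay, with a stated time of 48 h; a higher number here means a weaker inhibitor of growth, a lower number a stronger inhibitor of growth. Compound 1 `Nc1nn(C(=O)Nc2ccc(Cc3ccccc3)cc2)c2ccccc12` gives 58200 nM, and compound 2 `Nc1nn(C(=O)Nc2ccc(Cc3ccccc3)cc2)c2ccc(Cl)cc12` gives 31500 nM. Among the compounds with values here, the only measured step, a 1.8-fold lower number from compound 1 to compound 2 (0.27 log units; within the scatter), is chloro in place of hydrogen on an aromatic carbon, and it leaves compound 2 with the lower of the two numbers, though the two values sit within the scatter of each other.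

Compound 3 `Nc1ccc2c(c1)c(N)nn2C(=O)Nc1ccc(Cc2ccccc2)cc1` is the next point. It differs from compound 2 by amino in place of chloro on an aromatic carbon. Within the data shown here, no measured step involves an amino group, so the step from compound 1 to compound 2 bears on it only loosely: a single-atom change at this position produced nothing beyond the scatter. Compound 3 is therefore expected to show a 1.4-fold higher number from compound 2 to compound 3 (0.15 log units; within the scatter), a change not beyond the scatter. The estimate for compound 3 is 45000 nM, within 15000 nM to 150000 nM.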

Compound 3, concentration for total growth inhibition: 43900 nM
Estimate against measurement, compound 3: 1.0-fold (0.01 log units) above, within the range that was stated.
By their numbers in this assay, from the lowest: compounds 2, 3 and 1 (each within the scatter of the next).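

In this assay, amino in place of chloro gives a 1.4-fold higher number from compound 2 to compound 3 (0.14 log units; within the scatter), and amino in place of hydrogen gives a 1.3-fold lower number from compound 1 to compound 3 (0.12 log units; within the scatter). The earlier compounds shown here showed only that chloro and hydrogen could not be told apart on this aromatic carbon; now a nitrogen-bearing group joins them, and none of the three substituents separates from the others beyond the scatter. Nothing available accounts for this result.

Going by these compounds, whether a methoxy group, an acetamide or a carboxylic acid on this same carbon would carry the number beyond the scatter stays open. On these data alone, it is also open whether a change elsewhere on the shared core, such as a fluoro or hydroxyl group, would matter more than any of the changes at this carbon.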